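A few compounds are considered here, and "the series" means these few. Any claim that something is new, unique, unknown or untested is made for them only; others in the source may bear on it.

In a functional assay for inhibition, with Homo sapiens as the target (a lower number here means a stronger inhibitor, a higher number a weaker inhibitor), compound 1 `CC(=O)c1cc(-c2ccccc2)c2ccc(OCc3cccc(C4(O)CCOCC4)c3)cc2c1` gives 2 nM and compound 2 `COC(=O)c1cc(-c2ccccc2)c2ccc(OCc3cccc(C4(O)CCOCC4)c3)cc2c1` gives 3 nM, so the two cannot be told apart. Compound 3 `OC1(c2cccc(COc3ccc4c(-c5ccccc5)cc(-c5nn[nH]n5)cc4c3)c2)CCOCC1` keeps the rest of compound 2 but changes one group: 2H-tetrazol-5-yl in place of methoxycarbonyl on an aromatic carbon. In short, it carries 2H-tetrazol-5-yl in place of methoxycarbonyl on an aromatic carbon. Within the data shown here, only one measured step bears on this, a 1.5-fold higher number from compound 1 to compound 2 (0.18 log units; within the scatter). That step exchanged one carbonyl group for another, whereas here the methoxycarbonyl leaves entirely and a ring enters, so it offers only a weak guide. With so little evidence, a modest loss of strength is expected, with wide uncertainty. The estimated move is a 3.3-fold higher number from compound 2 to compound 3 (0.52 log units; beyond the scatter), towards a higher number in this assay. For compound 3 the estimated value is 10 nM, with an expected range of 2 nM to 50 nM.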

Compound 3, half-maximal inhibitory concentration: > 700 nM
Compound 3: only a limit was reported (the forecaster's own chance of this, stated with the estimate: 5%); at least 70-fold (1.84 log units) between middle value and limit.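

In this assay, compound 3 is reported only as a limit, not as a number: the limit of > 700 nM in this assay, at which 1 of the 3 values shown sits. The earlier pair showed this aromatic carbon accepting one carbonyl group in place of another within the scatter, but the new result shows that it does not accept every group: 2H-tetrazol-5-yl in place of methoxycarbonyl brings an at least 230-fold higher number from compound 2 to compound 3 (2.36 log units; beyond the scatter), and the same ring in place of acetyl brings an at least 350-fold higher number from compound 1 to compound 3 (2.54 log units; beyond the scatter). This single exchange changes several things at once, since a five-membered aromatic ring and a hydrogen-bond donor enter while methoxycarbonyl leaves, so the compounds shown cannot single out which of these matters.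

Going by these compounds, whether a carboxylic acid, an amide or a nitrile on this carbon would track the two carbonyl compounds or compound 3 stays open. On these data alone, the true value of compound 3 also remains unknown.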